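Replacing the dinitrophenyl ether with a catechol ether

The source may report more compounds than this note shows. Statements on the series, on what has been measured and on what is new or still open speak of the compounds shown alone.

Compound 1 `O=C(NCCNS(=O)(=O)c1ccc(-c2ccccc2OCc2cccc(O)c2)s1)Nc1cc(C(F)(F)F)cc(C(F)(F)F)c1`: 4000 nM
Compound 2 `Nc1ccc(Oc2ccccc2-c2ccc(S(=O)(=O)NCCNC(=O)Nc3cc(C(F)(F)F)cc(C(F)(F)F)c3)s2)cc1`: > 50000 nM
Compound 3 `O=C(NCCNS(=O)(=O)c1ccc(-c2ccccc2Oc2ccc([N+](=O)[O-])c([N+](=O)[O-])c2)s1)Nc1cc(C(F)(F)F)cc(C(F)(F)F)c1`: 1900 nM

In a functional assay on HL-60 cells (Homo sapiens) for inhibition, read by CCK-8 assay, with a stated time of 48 h (a lower number here means a stronger inhibitor, a higher number a weaker inhibitor), compound 3 gives 1900 nM, the lowest of the numbers obtained, with compound 1 nearest at a 2.1-fold lower number from compound 1 to compound 3 (0.32 log units; beyond the scatter). For compound 2 the assay reports only a limit, > 50000 nM (the limit of > 50000 nM in this assay, at which 1 of the 3 values shown sits). Compound 4 `O=C(NCCNS(=O)(=O)c1ccc(-c2ccccc2Oc2ccc(O)c(O)c2)s1)Nc1cc(C(F)(F)F)cc(C(F)(F)F)c1` differs from compound 3 in one place: 3,4-dihydroxyphenyl in place of 3,4-dinitrophenyl on an oxygen on an aromatic ring. Going by the values given here, two measured steps bear on this. The exchange of the 4-aminophenyl for the 3,4-dinitrophenyl gave an at least 26-fold lower number from compound 2 to compound 3 (1.42 log units; beyond the scatter), and the exchange of the 3-hydroxybenzyl for the same group gave a 2.1-fold lower number from compound 1 to compound 3 (0.32 log units; beyond the scatter). Both phenyl groups that carry hydrogen-bond donors in place of the nitro groups sit higher than compound 3, one of them only as a limit. Compound 4 is therefore expected to move upward from compound 3, by a step estimated at a 4.7-fold higher number from compound 3 to compound 4 (0.68 log units; beyond the scatter), with real uncertainty about whether the assay will return a number at all. The estimate for compound 4 is 9000 nM, within 2500 nM to 45000 nM.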

Compound 4, half-maximal inhibitory concentration: 10500 nM
For compound 4 the middle estimate is 1.2-fold (0.07 log units) below the measured one; the measured number falls inside the stated range.
By their numbers in this assay, from the lowest: compound 3; then compound 1; then compound 4. At a limit, above all of these: compound 2.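

In this assay, putting hydroxyl groups where compound 3 carries its nitro groups, on the same phenyl ring and the same oxygen, gives a 5.5-fold higher number from compound 3 to compound 4 (0.74 log units; beyond the scatter), so the lower number of compound 3 does not carry over to this 3,4-dihydroxyphenyl group. The 3,4-dihydroxyphenyl group also does not match the 3-hydroxybenzyl group on this oxygen, with a 2.6-fold higher number from compound 1 to compound 4 (0.42 log units; beyond the scatter). Unlike the 4-aminophenyl group of compound 2, which is known only as a limit, it returns a measured number, and the step of an at least 4.7-fold lower number from compound 2 to compound 4 (0.67 log units; beyond the scatter) is a bound rather than a measured gap: the limit of > 50000 nM in this assay, at which 1 of the 4 values shown sits.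

Going by these compounds, whether a 3,4-dimethoxyphenyl group, with methyl ethers in place of the hydroxyl groups, would sit nearer compound 3 or compound 4 stays open. So does whether a 3,4-diaminophenyl group would follow compound 2 or compound 4.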